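The compounds below may be only part of what the source reports. "The series", "measured", "known", "first", "only" and "open" are said of these compounds alone.

Three compounds have readings in an ADME assay on L6 cells (Rattus norvegicus) for cytotoxicity; a lower number here means a stronger inhibitor, a higher number a weaker inhibitor. Compound 1 `c1ccc2[nH]c(-c3ccc(-c4cc5cc(-c6nc7ccccc7[nH]6)ccc5o4)cc3)nc2c1` gives 6700 nM, and compound 3 `N=C(N)c1cccc(-c2cc3ccc(C(=N)N)cc3o2)c1` gives 131000 nM, so compound 3 has the higher number of these two.

In this assay compound 2 `CC(C)NC(=N)c1ccc(-c2cc3ccc(C(=N)NC(C)C)cc3o2)cc1` reads > 199000 nM, which is a limit of the assay and not a number. Its standing is therefore (the limit of > 199000 nM in this assay, at which 1 of the 3 values shown sits), with no exact value to start from.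

Compound 4 `CC(C)NC(=N)c1ccc(-c2cc3ccc(C(=N)NC(C)C)cc3o2)c(O)c1` differs from compound 2 in one place hydroxy in place of hydrogen on an aromatic carbon, ortho to a large group. Among the measured compounds shown here, no measured pair isolates this change, so the expectation is loose. Only a modest step is expected in this assay, and if the number moves, it can be read only toward the lower side, or the reading may stay at the limit. The nearest guide is compound 3 at 131000 nM, which suggests that a number in this high range is plausible, whereas compound 1 at 6700 nM is far lower and is not expected to be approached.

The expected change is an at least 1.6-fold lower number from compound 2 to compound 4 (0.21 log units; that floor lies within the scatter). For compound 4 the estimated value is 120000 nM, with an expected range from 50000 nM to 200000 nM.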

Compound 4, half-maximal inhibitory concentration: > 183000 nM
Compound 4: only a limit was reported (the forecaster's own chance of this, stated with the estimate: 40%); middle value at least 1.5-fold (0.18 log units) from the limit.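

Compound 2 stands at > 199000 nM in this assay, a limit of the assay and not a number. Among the compounds shown here, compound 4 stands at > 183000 nM, likewise a limit, so no step between compound 2 and compound 4 can be read. The compounds shown leave open whether hydroxy in place of hydrogen on an aromatic carbon changes the number in this assay at all.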